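A few compounds are considered here, and "the series" means these few. Any claim that something is new, unique, unknown or untested is made for them only; others in the source may bear on it.

In a functional assay on HepG2 cells (Homo sapiens) for inhibition, read by MTT assay, with a stated time of 72 h (a higher number here means a weaker inhibitor, a lower number a stronger inhibitor), compound 1 `COc1ccccc1/C=C/C(=O)c1c(OC)cc(O)c(CC=C(C)C)c1O` gives 14600 nM and compound 2 `COc1cc(O)c(CC=C(C)C)c(O)c1C(=O)/C=C/c1ccc(Cl)cc1` gives 10100 nM. Compound 2 therefore stands level with compound 1 within the scatter, and only these two numbers are available. Next is compound 3 `COc1cc(O)c(CC=C(C)C)c(O)c1C(=O)/C=C/c1ccc([N+](=O)[O-])cc1`, which has nitro in place of chloro on an aromatic carbon, para to a large group: nitro in place of chloro on an aromatic carbon. Among the measured compounds shown here, the one measured step bearing on this change also alters the substituent on that aromatic ring: a 1.4-fold lower number from compound 1 to compound 2 (0.16 log units; within the scatter). For the measured compounds named here, no measured compound carries nitro, so this single step is thin support. With nothing larger than that step on record, no change beyond the scatter is expected in this assay. The expected step is a 1.0-fold lower number from compound 2 to compound 3 (0.00 log units; within the scatter). For compound 3 the estimated value is 10000 nM, with an expected range of 4500 nM to 22000 nM.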

Compound 3, half-maximal inhibitory concentration: 12400 nM
Compound 3: the middle estimate sits 1.2-fold (0.09 log units) below what was measured; measured number inside the range.
By their numbers in this assay, from the lowest: compounds 2, 3 and 1 (each within the scatter of the next).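

In this assay, among the compounds shown here, nitro in place of chloro on an aromatic carbon, para to a large group, gives a 1.2-fold higher number from compound 2 to compound 3 (0.09 log units; within the scatter) and is the first direct reading of a change at this position with the rest of the structure held constant. Against the 2-methoxyphenyl group, the 4-nitrophenyl group gives a 1.2-fold lower number from compound 1 to compound 3 (0.07 log units; within the scatter) and so adds a second step within the scatter, leaving compounds 1, 2 and 3 without a ranking. No measurement on hand offers an explanation for this flat reading.

From the compounds shown here alone, whether any group at this position can move the number beyond the scatter remains open, for example an amine or a carboxylic acid on the same aromatic carbon. The compounds shown also leave open how the series responds to changes elsewhere on the shared core, since all three carry it unchanged.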